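The source may hold more compounds than are shown below. What is called first, only, known or untested is meant among the compounds shown, and "the series" means these compounds.

Measured in a functional assay on CWR22R cells (Homo sapiens) for antiproliferative activity, read by propidium iodide staining, with a stated time of 96 h; on this read-out lower numbers stand for stronger inhibition and higher numbers for weaker inhibition:
- compound 1 `CC(O)(COc1cccc(S(F)(F)(F)(F)F)c1)C(=O)Nc1ccc([N+](=O)[O-])cc1C(F)(F)F`: 15500 nM
- compound 2 `CC(O)(COc1ccc(C#N)cc1)C(=O)Nc1cccc(S(F)(F)(F)(F)F)c1`: 32500 nM
- compound 3 `CC(O)(CS(=O)(=O)c1cccc(S(F)(F)(F)(F)F)c1)C(=O)Nc1cccc(S(F)(F)(F)(F)F)c1`: 15400 nM

Compound 3, at 15400 nM, lies within the scatter of compound 1, at 15500 nM. Compound 2, at 32500 nM, gives a higher number than compound 3, a gap beyond the scatter.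

Compound 4 `CC(O)(CS(=O)(=O)c1cccc(C(F)(F)F)c1)C(=O)Nc1cccc(S(F)(F)(F)(F)F)c1` has not yet been measured in this assay. It differs from compound 3 in one place: a group of 4 heavy atoms (1 carbon, 3 fluorine; no ring) in place of a group of 6 heavy atoms (5 fluorine, 1 sulfur; no ring), on an aromatic carbon. A trifluoromethyl group enters on an aromatic carbon, meta to a large group, and the other group of the same kind as the one that leaves stays in place.

Among the compounds with values here, no pair of measured compounds differs in only one place, so the data offer no direct gauge of this exchange. Only a small step is expected, most likely none beyond the scatter, and any drift is expected towards a higher number. The expected step is a 1.3-fold higher number from compound 3 to compound 4 (0.11 log units; within the scatter). For compound 4 the estimated value is 20000 nM, with an expected range of 9000 nM to 45000 nM.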

Compound 4, half-maximal inhibitory concentration: 24600 nM
Beside the measured number, compound 4's estimate is 1.2-fold (0.09 log units) below it; the range from low to high includes it.
By their numbers in this assay, from the lowest: compounds 3, 1, 4 and 2 (each within the scatter of the next, the first and the last beyond it).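

In this assay the exchange of the group of five fluorine atoms and one sulfur for trifluoromethyl on the aromatic carbon gives a 1.6-fold higher number from compound 3 to compound 4 (0.20 log units; within the scatter) and is the only direct gauge of a single change among these compounds. At this position, then, the two groups cannot be told apart on this read-out, so the number does not depend on which of the two is present. No measured property is available that would explain this outcome.

From the compounds shown here alone, whether other groups on this aromatic carbon, such as an amine, a carboxylic acid or a single chlorine atom, would also leave the number within the scatter remains open. So does whether trifluoromethyl in place of the other group of the same kind, which stays in place here, would give a step of similar size.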